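Butyl for Isopropyl on a Second Core

The source may report more compounds than this note shows. Statements on the series, on what has been measured and on what is new or still open speak of the compounds shown alone.

Three compounds share a measurement in a functional assay on brain (Rattus norvegicus, strain Wistar) for inhibition; on this read-out lower numbers stand for stronger inhibition and higher numbers for weaker inhibition. Compound 1 `Cc1[nH]c(=O)n(C)c1-c1ccc(OCCC(C)C)cc1` gives 6600 nM in this assay. Compound 2 `CCCCCCOc1ccc(-c2c(C)[nH]c(=O)n2C)cc1` gives 7300 nM in this assay. The change between them is butyl in place of isopropyl on a saturated chain carbon, two bonds along the chain from an oxygen on an aromatic ring and it made a 1.1-fold higher number from compound 1 to compound 2 (0.04 log units; within the scatter). Compound 3 `Cc1[nH]c(=O)n(C2CCCCC2)c1-c1ccc(CC(C)C)cc1` gives 10900 nM in this assay; its number and those of compound 1 and compound 2 lie within the scatter of one another, so no order among the three can be read from them. The difference between the core of compound 3 and the core of compound 1 is not broken down here.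

Compound 4 `CCCCCc1ccc(-c2c(C)[nH]c(=O)n2C2CCCCC2)cc1` has not yet been measured in this assay. It differs from compound 3 by butyl in place of isopropyl on a saturated chain carbon bound to an aromatic carbon. Among the compounds with values here, this is the same kind of change as the one from compound 1 to compound 2, but the place differs: there the chain carbon sat two bonds along the chain from an oxygen on an aromatic ring, here it is bound directly to an aromatic carbon. Within the data shown here, the step from compound 3 to compound 4 in this assay is expected to be a 1.1-fold higher number from compound 3 to compound 4 (0.04 log units; within the scatter), because a 1.1-fold higher number from compound 1 to compound 2 (0.04 log units; within the scatter) stayed within the scatter and is the only precedent for this change. Among the measured compounds shown here, for compound 4 the estimate in this assay is 12000 nM, expected to fall between 5000 nM and 28000 nM, with the single precedent on a different core leaving the range wide.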

Compound 4, half-maximal inhibitory concentration: 10600 nM
Compound 4: middle estimate off by 1.1-fold (0.05 log units), on the high side; the range from low to high includes it.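

In this assay, butyl in place of isopropyl on a saturated chain carbon bound to an aromatic carbon gave a 1.0-fold lower number from compound 3 to compound 4 (0.01 log units; within the scatter). Set beside the earlier step on the other core, the new step does not differ from it: the same change on two cores in this assay, a 1.1-fold higher number (0.04 log units; within the scatter) from compound 1 to compound 2 and a 1.0-fold lower number (0.01 log units; within the scatter) from compound 3 to compound 4, 1.1-fold (0.06 log units) apart, within the scatter of two such steps. In these two pairs, then, the change stayed within the scatter on both cores, and the result carried over despite the difference in where the chain carbon sits; this does not show that it would hold on a third core, and two pairs cannot show whether the same outcome on both cores has one shared origin or two separate ones.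

The compounds shown leave open how the number in this assay would respond to a chain longer than any here, or to a chain ending in an amine or a carboxylic acid. Within the data shown here, they also leave open what the core alone contributes, since compound 1 and compound 3 differ in more than one place and no pair isolates that difference.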